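This account rests on a few compounds, and the source may have more. Where it says the series, first, only, none or still open, it means among the compounds named here.

Measured so far in this series:
compound 1 `O=C(NCN1CCC(c2cccc[n+]2[O-])CC1)c1cnccc1Cl` — 1290 nM
compound 2 `CC(C)Oc1cccc(NC(=O)CN2CCC(c3cccc[n+]3[O-])CC2)c1` — 555 nM
compound 3 `Cc1cc(F)ccc1NC(=O)CN1CCC(c2cccc[n+]2[O-])CC1` — 60 nM

In a functional assay on HEK293 cells for agonist activity at D(4) dopamine receptor (Homo sapiens), read by FLIPR (on this read-out higher numbers stand for an effect only at larger amounts of compound and lower numbers for an effect already at smaller amounts), compound 1 stands at the highest number of the three. Compound 2 sits nearer to it, with a gap beyond the scatter, while compound 3 lies far below it. The two neighbours carry anilide groups rather than a pyridine carboxamide, so they say nothing direct about the aromatic group on the carbonyl.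

Compound 4 `O=C(NCN1CCC(c2cccc[n+]2[O-])CC1)c1ccccn1` differs from compound 1 by pyridin-2-yl in place of 4-chloropyridin-3-yl on a carbonyl carbon. Going by the values given here, no measured pair shows that exchange, so its direction is open. For the step from compound 1 to compound 4 a small move is expected, possibly within the scatter, and the estimate is a 1.2-fold higher number from compound 1 to compound 4 (0.07 log units; within the scatter). Compound 4 is therefore expected to give 1500 nM in this assay, within 450 nM to 5000 nM.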

Compound 4, half-maximal effective concentration: 3150 nM
For compound 4 the middle estimate is 2.1-fold (0.32 log units) below the measured one, within the range that was stated.
By their numbers in this assay, from the lowest: compound 3; then compound 2; then compound 1; then compound 4.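

In this assay, going by these compounds alone, the exchange of 4-chloropyridin-3-yl for pyridin-2-yl on a carbonyl carbon gives a 2.4-fold higher number from compound 1 to compound 4 (0.39 log units; beyond the scatter) and is the first direct reading at this position. The group on this carbonyl therefore matters, though the step is modest and the effect still requires larger amounts of compound. Nothing available separates the loss of chlorine from the change in how the pyridine ring is attached.

Still open, as far as these compounds go, is whether unsubstituted pyridin-3-yl would separate those two changes. Also open, from the compounds shown here alone, is how a phenyl or cyclohexyl group would read on the same carbonyl.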